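Moving the methyl on the pyridine of a thiosemicarbazone

The compounds below may be only part of what the source reports. "The series", "measured", "known", "first", "only" and "open" are said of these compounds alone.

Compound 1 `Cc1cccc(/C(N)=N/NC(=S)N2CCN(c3ccccn3)CC2)n1` gives 86.3% in a functional assay on HeLa cells (Homo sapiens) for cytotoxicity, read by MTT assay, with a stated time of 72 h, tested at 30 uM; a higher number here means more inhibition of growth at the concentration tested, a lower number less inhibition of growth. Compound 3 `Cc1cccc(/C(N)=N/NC(=S)N2CCSCC2)n1` gives 85.3%, and compound 2 `N/C(=N\NC(=S)N1CCCC1)c1ccc(F)cn1` gives 81.2%. Compound 1 thus has the highest of the three numbers, yet both gaps to it lie within the scatter, so no order among the three can be claimed. Compound 4 `Cc1ccnc(/C(N)=N/NC(=S)N2CCN(c3ccccn3)CC2)c1` differs from compound 1 in one place: 4-methylpyridin-2-yl in place of 6-methylpyridin-2-yl on a carbon with a double bond to nitrogen. Among the measured compounds shown here, no measured pair here bears on a change of this kind, and the three numbers so far sit close together, so the expected step is a number 2.3 percentage points lower from compound 1 to compound 4 (within the scatter), within the scatter and in no particular direction. Compound 4 is therefore estimated at 84%, with a range from 70% to 94%.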

Compound 4, percent growth inhibition at one concentration: 77%
For compound 4 the middle estimate is 7 percentage points above the measured one; the range from low to high includes it.
By their numbers in this assay, from the lowest: compounds 4, 2, 3 and 1 (each within the scatter of the next).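

Placing 4-methylpyridin-2-yl in place of 6-methylpyridin-2-yl gives the first direct reading of a change at this carbon in this assay, and the step is a number 9.3 percentage points lower from compound 1 to compound 4 (within the scatter). Even with the same atoms joined differently, this single change therefore cannot be told apart from repeated measurement. No measurement here gives a cause for the step.

From the compounds shown here alone, it remains open how a pyridin-2-yl with no methyl, or with a methoxy group in place of the methyl, would read. Going by these compounds, whether the same swap would read alike on compound 3 also remains open.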